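Replacing a Pyrrolyl Ring with a Hydroxylated Chain

This account rests on a few compounds, and the source may have more. Where it says the series, first, only, none or still open, it means among the compounds named here.

Of the compounds shown here, three have been measured in an assay on cell membranes for binding affinity to adenosine receptor A1 (Cavia porcellus), read by radioligand binding; on this read-out lower numbers stand for stronger inhibition and higher numbers for weaker inhibition. Compound 1 `CCCn1c(=O)c2nc(CC(C)(C)C)[nH]c2n(CCC)c1=O` gives 49 nM, compound 2 `CCCn1c(=O)c2nc(-c3cccn3C)[nH]c2n(CCC)c1=O` gives 140 nM, and compound 3 `CC(C)(C)CNc1ncnc2c1ncn2C1O[C@H](CO)[C@@H](O)[C@H]1O` gives 17 nM. Compound 2 thus has the highest number of the three, with compound 1 nearest to it and compound 3 furthest. Compound 4 `CCCn1c(=O)c2nc(C(O)(CC)CC)[nH]c2n(CCC)c1=O` differs from compound 2 in one place: 1-ethyl-1-hydroxypropyl in place of 1-methyl-1H-pyrrol-2-yl on an aromatic carbon. Within the data shown here, the only measured step that bears on this is a 2.9-fold higher number from compound 1 to compound 2 (0.46 log units; beyond the scatter), in which neopentyl gave a lower number than 1-methyl-1H-pyrrol-2-yl. Since 1-ethyl-1-hydroxypropyl, like neopentyl, has no ring, a step back toward compound 1 is expected, roughly a 1.8-fold lower number from compound 2 to compound 4 (0.24 log units; within the scatter). Compound 4 is therefore estimated at 80 nM, between 30 nM and 250 nM.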

Compound 4, inhibition constant: 170 nM
Compound 4: middle estimate off by 2.1-fold (0.33 log units), on the low side, and the stated range covers the measured number.
By their numbers in this assay, from the lowest: compound 3; then compound 1; then compounds 2 and 4 (each within the scatter of the next).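

Having no ring at this position does not by itself bring the number back toward compound 1: with 1-ethyl-1-hydroxypropyl on the aromatic carbon, the step is a 1.2-fold higher number from compound 2 to compound 4 (0.08 log units; within the scatter). Two ring-free groups can also differ here, since this assay gives a 3.5-fold higher number from compound 1 to compound 4 (0.54 log units; beyond the scatter). Nothing available explains that gap. Still open, going by these compounds, is what the hydroxyl contributes, which a 1-ethylpropyl group, the same chain with hydrogen in place of the hydroxyl, could test. An amine in place of the hydroxyl would be a further probe of this position.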